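Dimethoxyphenyl Replacing Fluorophenyl on the Aminopyrimidine Core

A few compounds are considered here, and "the series" means these few. Any claim that something is new, unique, unknown or untested is made for them only; others in the source may bear on it.

Measured so far:
compound 1 `COc1ccc(Nc2cc(Nc3ccc(Oc4ccncc4-c4cccnc4)c(F)c3)ncn2)cc1`: 1010 nM
compound 2 `Fc1ccc(Nc2cc(Nc3ccc(Oc4ccncc4-c4cccnc4)c(F)c3)ncn2)cc1`: 160 nM

Among the measured compounds shown here, in a functional assay on MKN-45 cells (Homo sapiens) for cytotoxicity, read by MTT assay, with a stated time of 72 h (on this read-out lower numbers stand for stronger inhibition and higher numbers for weaker inhibition), compound 2 gives the lowest of the two numbers known, and the step of a 6.3-fold lower number from compound 1 to compound 2 (0.80 log units; beyond the scatter) separates it from compound 1. Compound 3 `COc1cc(Nc2cc(Nc3ccc(Oc4ccncc4-c4cccnc4)c(F)c3)ncn2)cc(OC)c1` carries 3,5-dimethoxyphenyl in place of 4-fluorophenyl on a nitrogen on an aromatic ring. For the measured compounds named here, the one step known bears on it only loosely: it traded methoxy for fluoro and lowered the number, so putting two methoxy groups back in place of fluoro is expected to raise it. Compound 3 is therefore estimated at 800 nM, within 200 nM to 3200 nM, a step of a 5.0-fold higher number from compound 2 to compound 3 (0.70 log units; beyond the scatter).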

Compound 3, half-maximal inhibitory concentration: 1750 nM
The estimate for compound 3 lay 2.2-fold (0.34 log units) below the measured number, and the stated range covers the measured number.
By their numbers in this assay, from the lowest: compound 2; then compounds 1 and 3 (each within the scatter of the next).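

In this assay, 3,5-dimethoxyphenyl in place of 4-fluorophenyl on this nitrogen gives an 11-fold higher number from compound 2 to compound 3 (1.04 log units; beyond the scatter), while 3,5-dimethoxyphenyl in place of 4-methoxyphenyl gives a 1.7-fold higher number from compound 1 to compound 3 (0.24 log units; within the scatter). Among these three compounds, the two methoxy-bearing groups therefore cannot be told apart, and only 4-fluorophenyl stands clear of them. No measurement offered here explains this difference. From the compounds shown here alone, whether the low number of compound 2 depends on fluoro itself or simply on the lack of methoxy stays open, and an unsubstituted phenyl or a phenyl bearing an amine would help to separate the two.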